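Working notes: aryl ketone exchange on the shared core

A few compounds are considered here, and "the series" means these few. Any claim that something is new, unique, unknown or untested is made for them only; others in the source may bear on it.

Measured so far:
Compound 1 `COc1cc(-c2nnc3n2NC(c2cccs2)C(C(=O)c2ccc(C)cc2)S3)cc(OC)c1OC` gives 12700 nM in a functional assay on A549 cells (Homo sapiens) for cytotoxicity, read by MTT assay, with a stated time of 48 h; a higher number here means a weaker inhibitor, a lower number a stronger inhibitor.
Compound 2 `COc1cc(-c2nnc3n2NC(c2ccco2)C(C(=O)c2ccc(C)cc2)S3)cc(OC)c1OC` reaches only the assay limit, > 100000 nM.
Compound 3 `COc1cc(-c2nnc3n2NC(c2ccco2)C(C(=O)c2ccccc2C)S3)cc(OC)c1OC` gives 80000 nM.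

Among the numbers shown, compound 1 stands lowest. Compound 4 `COc1cc(C(=O)C2Sc3nnc(-c4cc(OC)c(OC)c(OC)c4)n3NC2c2cccs2)cc(OC)c1OC` keeps its core and differs by 3,4,5-trimethoxyphenyl in place of 4-methylphenyl on a carbonyl carbon.

Among the measured compounds shown here, the one measured step at that same carbonyl carbon, an at least 1.2-fold lower number from compound 2 to compound 3 (0.09 log units; that floor lies within the scatter), was small, and the larger step of an at least 7.8-fold higher number from compound 1 to compound 2 (0.89 log units; beyond the scatter) sits elsewhere, on the saturated ring carbon, so it does not bear on this exchange. Accordingly only a modest change is expected for compound 4, a 1.1-fold lower number from compound 1 to compound 4 (0.02 log units; within the scatter), with the direction open. Compound 4 is estimated at 12000 nM, within 4000 nM to 40000 nM.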

Compound 4, half-maximal inhibitory concentration: > 100000 nM
Compound 4 gave a limit, no number; the forecaster's own chance of this, stated with the estimate: 5%; middle value at least 8.3-fold (0.92 log units) away from the limit.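

At the carbonyl carbon, 3,4,5-trimethoxyphenyl in place of 4-methylphenyl gives an at least 7.8-fold higher number from compound 1 to compound 4 (0.89 log units; beyond the scatter) in this assay, so this exchange is not neutral on the core of compound 1. The earlier step at this carbon did not show this, as its floor lay within the scatter. Compound 4 gives only a limit, > 100000 nM, and the step is a floor with its true size unknown: the limit of > 100000 nM in this assay, at which 2 of the 4 values shown sit.

As far as these compounds go, whether the full set of methoxy groups is needed for this loss stays open. Also open, from the compounds shown here alone, is the outcome with an amine or a carboxylic acid on the aryl ring at this carbonyl carbon.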